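The compounds below may be only part of what the source reports. "The series", "measured", "known", "first", "only" and "open" are said of these compounds alone.

In a functional assay on Bel-7402 cells (Homo sapiens) for cytotoxicity, read by MTT assay, with a stated time of 48 h (on this read-out lower numbers stand for stronger inhibition and higher numbers for weaker inhibition), compound 1 `CCn1cc(-c2nc3ccccc3s2)c(=O)c2cc(F)c(N3CCNCC3)cc21` gives 24300 nM. Compound 2 `CCn1cc(-c2nc3ccccc3s2)c(=O)c2cc(F)c(N3CCN(C)CC3)cc21` carries methyl in place of hydrogen on an amine nitrogen in a ring on the core of compound 1, and in this assay compound 2 gives 24000 nM, so that a 1.0-fold lower number from compound 1 to compound 2 (0.01 log units; within the scatter). Compound 3 `CCn1cc(-c2nc3ccc(N)cc3[nH]2)c(=O)c2cc(F)c(N3CCNCC3)cc21` differs from compound 1 by a group of 10 heavy atoms (7 carbon, 3 nitrogen; one five-membered aromatic ring with 2 hetero atoms, one six-membered aromatic ring of carbon only) in place of a group of 9 heavy atoms (7 carbon, 1 nitrogen, 1 sulfur; one five-membered aromatic ring with 2 hetero atoms, one six-membered aromatic ring of carbon only), on an aromatic carbon; in this assay compound 3 gives 92100 nM, and a 3.8-fold higher number from compound 1 to compound 3 (0.58 log units; beyond the scatter). Compound 4 `CCn1cc(-c2nc3ccc(N)cc3[nH]2)c(=O)c2cc(F)c(N3CCN(C)CC3)cc21` has not yet been measured in this assay. It stands to compound 3 as compound 2 stands to compound 1, carrying (methyl in place of hydrogen on an amine nitrogen in a ring), the same change in the same place, now made on the core of compound 3. Because a 1.0-fold lower number from compound 1 to compound 2 (0.01 log units; within the scatter) lay within the scatter, the expected step here is a 1.0-fold lower number from compound 3 to compound 4 (0.01 log units; within the scatter). The single caution is that this change has been measured only once, on the core of compound 1, and the two cores differ as described, so the expectation rests on one pair alone. For compound 4 the expected value in this assay is 90000 nM, with an estimated range from 45000 nM to 180000 nM.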

Compound 4, half-maximal inhibitory concentration: > 50000 nM
Compound 4: only a limit was reported; the forecaster's own chance of this, stated with the estimate: 25%; the middle value does not contradict the limit.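

In this assay compound 4 gives > 50000 nM, which is a limit of the assay and not a number. The step from methyl in place of hydrogen on the core of compound 3 therefore cannot be read, so this change is known on one core only, as a 1.0-fold lower number from compound 1 to compound 2 (0.01 log units; within the scatter), and the data neither show nor rule out that it carries over to the core of compound 3. The exchange of the two-ring group on an aromatic carbon can be read, as an at least 2.0-fold higher number from compound 2 to compound 4 (0.31 log units; beyond the scatter), and it runs the same way on the piperazin-1-yl and the 4-methylpiperazin-1-yl compounds: the same change on two cores in this assay, a 3.8-fold higher number (0.58 log units; beyond the scatter) from compound 1 to compound 3 and an at least 2.0-fold higher number (0.31 log units; beyond the scatter) from compound 2 to compound 4; the limit leaves it open whether they differ.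

The compounds shown leave open how a longer chain in place of methyl on the ring nitrogen would read in this assay. They also leave open how a carboxylic acid in place of the amine on the two-ring group would read there.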